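A few compounds are considered here, and "the series" means these few. Any claim that something is new, unique, unknown or untested is made for them only; others in the source may bear on it.

In a functional assay on RS4-11 cells (Homo sapiens) for inhibition, read by CCK-8 assay, with a stated time of 48 h (a lower number here means a stronger inhibitor, a higher number a weaker inhibitor), compound 3 `COc1ccc(Oc2ccccc2-c2ccsc2S(=O)(=O)N2CCN(C(=S)Nc3ccc(Cl)cc3)CC2)cc1OC` gives > 50000 nM, which is a limit of the assay and not a number. Compound 4 `O=S(=O)(c1sccc1-c1ccccc1Oc1ccc(O)c(O)c1)N1CCN(C(=S)Nc2ccc(Cl)cc2)CC1` differs from it in one place, on an oxygen on an aromatic ring: 3,4-dihydroxyphenyl in place of 3,4-dimethoxyphenyl on an oxygen on an aromatic ring. In words, 3,4-dihydroxyphenyl stands in place of 3,4-dimethoxyphenyl. Going by the values given here, no measured step covers this change directly. The nearest guide comes from compound 1 `O=C(Nc1cccc([N+](=O)[O-])c1)N1CCN(S(=O)(=O)c2sccc2-c2ccccc2Oc2ccc(O)c(O)c2)CC1`, at 9800 nM, and compound 2 `O=C(Nc1ccc(F)cc1)N1CCN(S(=O)(=O)c2sccc2-c2ccccc2Oc2ccc(O)c(O)c2)CC1`, at 6800 nM, which both carry the 3,4-dihydroxyphenyl group but differ from compound 4 elsewhere. Among the compounds with values here, the one measured step, a 1.4-fold lower number from compound 1 to compound 2 (0.16 log units; within the scatter), lies within the scatter and concerns a different place in the molecule, so it gives no size for this change. It does suggest that the values of such compounds may hold fairly steady when that other place changes. A move to a lower number in this assay, beyond the scatter, is therefore expected, estimated as an at least 6.2-fold lower number from compound 3 to compound 4 (0.79 log units; beyond the scatter). For compound 4 the estimated value is 8000 nM, with an expected range of 3000 nM to 25000 nM.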

Compound 4, half-maximal inhibitory concentration: 7500 nM
Estimate against measurement, compound 4: 1.1-fold (0.03 log units) above; low and high end bracket the measured number.
By their numbers in this assay, from the lowest: compounds 2, 4 and 1 (each within the scatter of the next). At a limit, above all of these: compound 3.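

In this assay, going by these compounds alone, 3,4-dihydroxyphenyl in place of 3,4-dimethoxyphenyl on an oxygen on an aromatic ring gives an at least 6.6-fold lower number from compound 3 to compound 4 (0.82 log units; beyond the scatter), the first measured step at this position, and it lies beyond the scatter. Compound 3 stands at a limit of the assay, so this step has a lower bound and no exact size: the limit of > 50000 nM in this assay, at which 1 of the 4 values shown sits. With 3,4-dihydroxyphenyl held in place, the change of group on the amine nitrogen in a ring gives a 1.1-fold higher number from compound 2 to compound 4 (0.04 log units; within the scatter) and a 1.3-fold lower number from compound 1 to compound 4 (0.12 log units; within the scatter), so compounds 1, 2 and 4 stay within the scatter of each other.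

The compounds shown leave open how far the full size of the step runs. They also leave open what a monohydroxyphenyl or a plain phenyl group would give on that oxygen, and so whether both hydroxyl groups are needed.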